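Pyrrolidinyl in place of cyclopentylamino on the shared core

The source may report more compounds than this note shows. Statements on the series, on what has been measured and on what is new or still open speak of the compounds shown alone.

The series shares the core of compound 1 `COc1cnc(-c2ccccn2)nc1NCc1ccccc1`, which in an in vitro ADME assay on microsomes from liver (Mus musculus) for metabolic stability, read by LC-MS, tested at 0.05 uM (a lower number here means slower removal, a higher number faster removal of the compound), gives 911 mL/min/kg. Compound 2 `COc1cnc(-c2ccccn2)nc1NCc1ccccc1F` gives 672 mL/min/kg in this assay, and the step of a 1.4-fold lower number from compound 1 to compound 2 (0.13 log units; within the scatter). Compound 3 `COc1cnc(-c2ccccn2)nc1NC1CCCC1` is reported only as a limit of this assay, > 1000 mL/min/kg, and so sits at the limit of > 1000 mL/min/kg in this assay, at which 1 of the 3 values shown sits. The step of an at least 1.0-fold higher number from compound 1 to compound 3 (0.04 log units; that floor lies within the scatter). Compound 4 `COc1cnc(-c2ccccn2)nc1N1CCCC1` differs from compound 3 by pyrrolidin-1-yl in place of cyclopentylamino on an aromatic carbon. Neither measured step involves this change, and both lie within the scatter, so no move beyond the scatter is expected in this assay for compound 4. Compound 4 is therefore estimated at 1100 mL/min/kg, with a range from 500 mL/min/kg to 2400 mL/min/kg. This estimate means an expected step that the limit leaves unreadable from compound 3 to compound 4.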

Compound 4, clearance: > 1000 mL/min/kg
Compound 4 ended at the assay's limit (the forecaster's own chance of this, stated with the estimate: 55%); the middle value does not contradict the limit.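

Compound 3 and compound 4 give no readable step, since both are reported only as a limit: the limit of > 1000 mL/min/kg in this assay, at which 2 of the 4 values shown sit. On these data alone, how far pyrrolidin-1-yl in place of cyclopentylamino shifts clearance in this assay stays open, as does where either compound truly lies beyond that limit.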